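Oxadiazole in Place of the Terminal Phenyl

The source may report more compounds than this note shows. Statements on the series, on what has been measured and on what is new or still open speak of the compounds shown alone.

Compound 1 `O=C(NO)c1cccc(OCc2ccc(-c3ccccc3)cc2)c1`: 19600 nM
Compound 2 `COc1ccc(C(=O)NO)cc1OCc1ccc(-c2ccccc2)cc1`: 3630 nM
Compound 3 `O=C(NO)c1cccc(OCc2ccc(/C=C/c3ccccc3)cc2)c1`: > 100000 nM, a limit of the assay rather than a number

All three were tested in an assay on isolated protein for inhibition of sphingomyelin phosphodiesterase (Homo sapiens), read by fluorescence, with a stated time of 30 min; on this read-out lower numbers stand for stronger inhibition and higher numbers for weaker inhibition. Compound 2 stands at the lowest of the two numbers given; its nearest neighbour is compound 1, and the move a 5.4-fold lower number from compound 1 to compound 2 (0.73 log units; beyond the scatter) separates them. For compound 3 the assay reports only a limit, (the limit of > 100000 nM in this assay, at which 1 of the 3 values shown sits), so the step of an at least 5.1-fold higher number from compound 1 to compound 3 (0.70 log units; beyond the scatter) is known only as a minimum.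

The untested compound 4 `CCc1nc(-c2ccc(COc3cc(C(=O)NO)ccc3OC)cc2)no1` differs from compound 2 in one place: 5-ethyl-1,2,4-oxadiazol-3-yl in place of phenyl on an aromatic carbon. For the measured compounds named here, no measured step makes exactly this change. The step of an at least 5.1-fold higher number from compound 1 to compound 3 (0.70 log units; beyond the scatter) is the one that bears on it, since it also alters the group at that same carbon, and it went towards weaker inhibition. The step of a 5.4-fold lower number from compound 1 to compound 2 (0.73 log units; beyond the scatter) touches the methoxy, which compound 4 keeps. A higher number than for compound 2 is therefore expected, most likely of modest size, a 3.3-fold higher number from compound 2 to compound 4 (0.52 log units; beyond the scatter). Compound 4 is estimated at 12000 nM, with a range from 2500 nM to 60000 nM.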

Compound 4, half-maximal inhibitory concentration: 8220 nM
The estimate for compound 4 lay 1.5-fold (0.16 log units) above the measured number; the measured number falls inside the stated range.
By their numbers in this assay, from the lowest: compound 2; then compound 4; then compound 1. At a limit, above all of these: compound 3.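

In this assay, exchanging the phenyl for the 5-ethyl-1,2,4-oxadiazol-3-yl group gives a 2.3-fold higher number from compound 2 to compound 4 (0.35 log units; beyond the scatter), so a five-membered aromatic ring with 3 hetero atoms can stand at this carbon at only a modest cost. The earlier step at this carbon, an at least 5.1-fold higher number from compound 1 to compound 3 (0.70 log units; beyond the scatter), ends at a limit of the assay and gives only a minimum, whereas this change has a size that can be read with the methoxy kept. Nothing shown here accounts for the cost of this change.

Compound 4 changes the ring and brings in the ethyl together, so the compounds shown do not separate the two, and the same oxadiazole carrying a methyl or a hydrogen in place of the ethyl would bear on that. As far as these compounds go, how a pyridine ring, or a terminal ring carrying an amine or a carboxylic acid, would fare at this carbon also remains open.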